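The source may report more compounds than this note shows. Statements on the series, on what has been measured and on what is new or still open speak of the compounds shown alone.

Working notes on the series, all read in an ADME assay on liver for metabolic stability, with Liver microsome (Homo sapiens) as the target, read by LC-MS, using microsomes (on this read-out lower numbers stand for slow clearance and higher numbers for fast clearance), as the sole measure. Compound 1 (`O=C(NCc1cc(Cl)ccc1-n1cnnn1)[C@@H]1CCNN1C(=O)[C@H](O)c1ccccc1`) gives < 16 mL.min-1.g-1 as a limit of the assay and not as a number. Compound 2 (`O=C(NCc1cc(Cl)ccc1-n1cnnn1)[C@@H]1C[C@H]2C[C@H]2N1C(=O)[C@H](O)c1ccccc1`) gives < 15 mL.min-1.g-1 as a limit as well. Compound 2 therefore has no exact position in the series, and the two other values available are also limits. Within the data shown here, no two measured compounds differ in one place, so the series offers no measured step to work from.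

Compound 4 (`CC(C)(C)[C@@H](O)C(=O)N1[C@@H]2C[C@@H]2C[C@H]1C(=O)NCc1cc(Cl)ccc1-n1cnnn1`) has not yet been measured. Its difference from compound 2 is tert-butyl in place of phenyl on a saturated chain carbon bound to a carbonyl carbon and an oxygen on a saturated carbon and, cut one bond further out, hydroxy(phenyl)methyl gives way to 1-hydroxy-2,2-dimethylpropyl. Compound 3 (`CC(C)(C)[C@@H](O)C(=O)N1N=CC[C@H]1C(=O)NCc1cc(Cl)ccc1-n1cnnn1`) already carries 1-hydroxy-2,2-dimethylpropyl on a different core and gives < 12 mL.min-1.g-1 as a limit, and this is the main support for the expectation that follows. In this assay no step beyond the scatter is expected, in either direction. The estimated change is a step that the limit leaves unreadable from compound 2 to compound 4 and is expected to stay within the usual scatter. Compound 4 is expected at 13 mL.min-1.g-1 with an estimated range of 8 mL.min-1.g-1 to 22 mL.min-1.g-1. Its result may well be only a limit too.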

Compound 4, intrinsic clearance in microsomes: 54 mL.min-1.g-1
Estimate against measurement, compound 4: 4.2-fold (0.62 log units) below, and the stated range ends below it.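

In this assay, among these compounds, this is the first change that yields a measured number rather than a limit: tert-butyl in place of phenyl on a saturated chain carbon bound to a carbonyl carbon and an oxygen on a saturated carbon gives an at least 3.6-fold higher number from compound 2 to compound 4 (0.55 log units; beyond the scatter). The change from hydroxy(phenyl)methyl to 1-hydroxy-2,2-dimethylpropyl is therefore not neutral on this core, and the size of the step remains a lower bound since its starting point is a limit: the limit of < 15 mL.min-1.g-1 in this assay, at which 1 of the 4 values shown sits. Compound 3 carries the same 1-hydroxy-2,2-dimethylpropyl on its own core and gives < 12 mL.min-1.g-1, a limit, so among the compounds shown this group does not bring a high number on every core.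

The compounds shown leave open whether the same change would raise the number on the cores of compound 1 and compound 3. Going by these compounds, it is also open whether isopropyl or cyclohexyl in place of phenyl on the same saturated chain carbon would stay at a limit or rise as compound 4 does.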